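Replacing a ketone-linked ring by a directly attached pyridine

The compounds below may be only part of what the source reports. "The series", "measured", "known", "first", "only" and "open" are said of these compounds alone.

Measured compounds:
- compound 1, `CC1(C)C=C(n2ccccc2=O)c2cc(C(=O)c3cccs3)ccc2O1`: 6.4
- compound 2, `CC1(C)C=C(n2ccccc2=O)c2cc(OCC(=O)c3ccccc3)ccc2O1`: 5.05
- compound 3, `CC1(C)C=C(n2ccccc2=O)c2cc(OC(=O)Nc3ccc(C(F)(F)F)cc3)ccc2O1`: 5.1

In a functional assay (aorta) with Rattus norvegicus as the target (a lower number here means a less potent compound, a higher number a more potent compound, by a factor of ten per unit of this negative logarithm), compound 1 gives 6.4, the highest of the three numbers. Compound 3 stands a long way lower in this assay at 5.1, and compound 2 stands lower still at 5.05; both gaps to compound 1 lie beyond the scatter. The two weaker compounds carry an oxygen-linked group at the same place on the shared core, whereas compound 1 carries its ring through a carbonyl.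

The unmeasured compound 4, `CC1(C)C=C(n2ccccc2=O)c2cc(-c3ccncc3)ccc2O1`, differs from compound 1 in one place: pyridin-4-yl in place of (thiophen-2-yl)carbonyl on an aromatic carbon. Going by the values given here, no pair of measured compounds shows a step of this kind, so nothing here tells how the attached ring, without its carbonyl, fares in this assay. The step from compound 1 to compound 4 is expected to go downward by a moderate amount, a number 0.70 log units lower from compound 1 to compound 4 (beyond the scatter), since only compound 1 with 6.4 reaches the higher range. Compound 4 is thus estimated at 5.7, within a range from 4.9 to 6.5.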

Compound 4, logarithm of the reciprocal of the active concentration, log(1/C): 6.68
Compound 4: middle estimate off by 0.98 log units, on the low side, outside the stated range (above it).
By their numbers in this assay, from the lowest: compounds 2 and 3 (each within the scatter of the next); then compounds 1 and 4 (each within the scatter of the next).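

In this assay, putting pyridin-4-yl in place of (thiophen-2-yl)carbonyl on this aromatic carbon is a number 0.28 log units higher from compound 1 to compound 4 (within the scatter), so the two groups cannot be told apart here. For this pair, then, the position does not depend on a carbonyl link: a directly attached six-membered aromatic ring with one hetero atom gives a response that matches that of a five-membered aromatic ring held through a carbonyl. No measurement is at hand that explains this match.

As far as these compounds go, whether a plain phenyl ring or pyridin-3-yl would give a similar number at this aromatic carbon remains open. So does the response to a directly attached thiophen-2-yl, which would separate the loss of the carbonyl from the change of ring.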